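Methyl added two bonds from the ring, in two series

The compounds below may be only part of what the source reports. "The series", "measured", "known", "first", "only" and "open" are said of these compounds alone.

Two pairs share one change: methyl in place of hydrogen on a saturated chain carbon, two bonds along the chain from an aromatic carbon. Compound 1 `CCc1ccccc1NS(=O)(=O)c1ccc(NC(=O)NCCCCl)cc1` and compound 2 `CCCc1ccccc1NS(=O)(=O)c1ccc(NC(=O)NCCCCl)cc1` form the measured pair; compound 3 `CCNC(=O)Nc1cccc(S(=O)(=O)Oc2ccccc2CC)c1` and compound 4 `CCCc1ccccc1OS(=O)(=O)c1cccc(NC(=O)NCC)c1` form the second, with compound 4 still to be measured. The difference between the two cores is not broken down here.

In a functional assay on MCF7 cells (Homo sapiens) for cytotoxicity, read by sulforhodamine B assay, with a stated time of 48 h (on this read-out lower numbers stand for stronger inhibition and higher numbers for weaker inhibition), compound 1 gives no number but a limit of the assay, > 200000 nM. In this assay compound 2 gives 35000 nM. From the compounds shown here alone, the step methyl in place of hydrogen on a saturated chain carbon, two bonds along the chain from an aromatic carbon thus reads an at least 5.7-fold lower number from compound 1 to compound 2 (0.75 log units; beyond the scatter); its true size stays open because the limit of > 200000 nM in this assay, at which 1 of the 3 values shown sits, sets only a floor to it. In this assay compound 3 gives 31000 nM, a value within the scatter of compound 2.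

The change methyl in place of hydrogen on a saturated chain carbon, two bonds along the chain from an aromatic carbon is the same as that from compound 1 to compound 2, the place being described in identical words. Going by these compounds, whether the step carries over to a different core is unknown, and the measured step is itself only a floor, so a more cautious expectation is taken. Compound 4 is expected to give about 10000 nM in this assay, with a plausible span from 3000 nM to 40000 nM. That expectation means a step of a 3.1-fold lower number from compound 3 to compound 4 (0.49 log units; beyond the scatter), resting on the pair compound 1 to compound 2 in this assay and on the starting value of compound 3, 31000 nM.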

Compound 4, half-maximal inhibitory concentration: 24000 nM
For compound 4 the middle estimate is 2.4-fold (0.38 log units) below the measured one; the range from low to high includes it.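

On the core of compound 3, the methyl step gives a 1.3-fold lower number from compound 3 to compound 4 (0.11 log units; within the scatter) in this assay, so ethyl and propyl cannot be told apart on this core. The step therefore does not carry over in size from one core to the other, and the two pairs alone do not show which difference between the cores separates them: the same change on two cores in this assay, an at least 5.7-fold lower number (0.75 log units; beyond the scatter) from compound 1 to compound 2 and a 1.3-fold lower number (0.11 log units; within the scatter) from compound 3 to compound 4, at least 4.4-fold (0.64 log units) apart, beyond the scatter of two such steps. From the compounds shown here alone, for compound 1 the value > 200000 nM is a limit of the assay, so the size of the first step stays open and only its floor can be compared: the limit of > 200000 nM in this assay, at which 1 of the 4 values shown sits.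

Still open, going by these compounds, is how a longer chain such as butyl, or an amine or a carboxylic acid at the end of the propyl chain, would read against compound 3 and compound 4 on this core. Also open, on these data alone, is whether butyl in the same place on the core of compound 1 would extend the first step or leave the reading where compound 2 stands.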